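The source may hold more compounds than are shown below. What is called first, only, known or untested is meant among the compounds shown, and "the series" means these compounds.

Compound 1 `C/C=C/C(=O)Nc1c(C(O)(C(F)(F)F)C(F)(F)F)ccc2ccccc12` gives 72 nM in an assay on LtK cells with ATP-sensitive inward rectifier potassium channel 11 (Homo sapiens) as the target; on this read-out higher numbers stand for an effect only at larger amounts of compound and lower numbers for an effect already at smaller amounts.
Compound 2 `O=C(CCc1ccccc1)Nc1c(C(O)(C(F)(F)F)C(F)(F)F)ccc2ccccc12` gives 1750 nM.
Compound 3 `COc1cccc(C(=O)Nc2c(C(O)(C(F)(F)F)C(F)(F)F)ccc3ccccc23)c1` gives 185 nM.

Compound 3 stands second highest of the three numbers, nearer to compound 1 than to compound 2: the step of a 2.6-fold higher number from compound 1 to compound 3 (0.41 log units; beyond the scatter) is modest, and a 9.5-fold lower number from compound 2 to compound 3 (0.98 log units; beyond the scatter) is modest in the other direction, whereas a 24-fold higher number from compound 1 to compound 2 (1.39 log units; beyond the scatter) is large. Compound 4 `O=C(Nc1c(C(O)(C(F)(F)F)C(F)(F)F)ccc2ccccc12)c1cccc(Cl)c1Cl` differs from compound 3 in one place: 2,3-dichlorophenyl in place of 3-methoxyphenyl on a carbonyl carbon. All three measured steps alter the group on the carbonyl carbon, but none compares two aromatic groups there, so the bearing of each is indirect. Since compound 3 with an aromatic group already sits close to compound 1 at 72 nM, a swap of one aromatic ring for another is expected to move this assay less than those steps, in no certain direction. For compound 4 the expected step is a 1.5-fold lower number from compound 3 to compound 4 (0.19 log units; within the scatter). Compound 4 is therefore estimated at 120 nM, within 30 nM to 500 nM.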

Compound 4, half-maximal effective concentration: > 10000 nM
Compound 4: a limit, no number; the forecaster's own chance of this, stated with the estimate: 3%; middle value at least 83-fold (1.92 log units) away from the limit.
By their numbers in this assay, from the lowest: compound 1; then compound 3; then compound 2. At a limit, above all of these: compound 4.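

Compound 4 stands at a limit, not at a number: the limit of > 10000 nM in this assay, at which 1 of the 4 values shown sits. An aromatic group on the carbonyl carbon therefore does not by itself keep the value close to that of compound 1, as 2,3-dichlorophenyl in place of 3-methoxyphenyl gives an at least 54-fold higher number from compound 3 to compound 4 (1.73 log units; beyond the scatter). The same group also lies beyond the groups of the other two compounds, with an at least 5.7-fold higher number from compound 2 to compound 4 (0.75 log units; beyond the scatter) and an at least 130-fold higher number from compound 1 to compound 4 (2.14 log units; beyond the scatter).

From the compounds shown here alone, whether a single chlorine, as in a 3-chlorophenyl group, would stay with compound 3 or follow compound 4 remains open. So does the effect of an amine or a carboxylic acid on that ring.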